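Benzyl to Methyl on Selenium Across Two Cores

This account rests on a few compounds, and the source may have more. Where it says the series, first, only, none or still open, it means among the compounds named here.

Two selenium-bearing cores were examined in a functional assay on MCF7 cells (Homo sapiens) for cytotoxicity, read by MTT assay, with a stated time of 72 h; on this read-out lower numbers stand for stronger inhibition of growth and higher numbers for weaker inhibition of growth. Compound 1 `O=C(/N=C(/NC(=O)c1cc(-c2ccccc2)nc2ccccc12)[Se]Cc1ccccc1)c1cc(-c2ccccc2)nc2ccccc12` gives 8460 nM in this assay, and compound 2 `C[Se]/C(=N\C(=O)c1cc(-c2ccccc2)nc2ccccc12)NC(=O)c1cc(-c2ccccc2)nc2ccccc12` gives 490 nM. The change between them, (hydrogen in place of phenyl on a saturated chain carbon bound to a selenium atom), produced a 17-fold lower number from compound 1 to compound 2 (1.24 log units; beyond the scatter). A second core appears in compound 3 `O=C(/N=C(/NC(=O)c1csc([N+](=O)[O-])c1)[Se]Cc1ccccc1)c1csc([N+](=O)[O-])c1`, which in this assay gives 24400 nM, the highest of the three numbers; the difference between the core of compound 3 and the core of compound 1 is not broken down here. Compound 4 `C[Se]/C(=N\C(=O)c1csc([N+](=O)[O-])c1)NC(=O)c1csc([N+](=O)[O-])c1` has not yet been measured. It differs from compound 3 by hydrogen in place of phenyl on a saturated chain carbon bound to a selenium atom, the same change as that from compound 1 to compound 2, at a place described in identical words. Since the step has been seen only once and on another core, its size for compound 3 is taken with caution, though the direction is expected to hold. For compound 4 an estimated 12-fold lower number from compound 3 to compound 4 (1.09 log units; beyond the scatter) is expected, resting on the measured 17-fold lower number from compound 1 to compound 2 (1.24 log units; beyond the scatter). Compound 4 is accordingly expected to give about 2000 nM, within a range from 700 nM to 8000 nM.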

Compound 4, concentration for 50% growth inhibition: 0.76 nM
Beside the measured number, compound 4's estimate is 2600-fold (3.42 log units) above it, and the stated range ends above it.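

On the core of compound 3, the change of benzyl to methyl gave a 32000-fold lower number from compound 3 to compound 4 (4.51 log units; beyond the scatter) in this assay and so went the same way as on the core of compound 1. The direction held on both cores shown, but that rests on only two pairs and says nothing about any other core. The size did not carry over, and the two pairs do not tell what in the cores sets the two steps apart: the same change on two cores in this assay, a 17-fold lower number (1.24 log units; beyond the scatter) from compound 1 to compound 2 and a 32000-fold lower number (4.51 log units; beyond the scatter) from compound 3 to compound 4, 1900-fold (3.27 log units) apart, beyond the scatter of two such steps

The compounds shown hold only benzyl and methyl on selenium, so it stays open how an ethyl group or a longer chain there would behave on either core, and whether the size of the step changes gradually or abruptly from one group to the next. Also open, going by these compounds, is how the same change would behave on a core carrying an amine or a carboxylic acid in place of the nitro groups.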